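Swapping a nitro for a sulfamoyl on a shared core

The compounds below may be only part of what the source reports. "The series", "measured", "known", "first", "only" and "open" are said of these compounds alone.

Measured so far:
compound 1 `NS(=O)(=O)c1ccc(-n2nc(Nc3ccccc3)c3c(=O)n(-c4ccccc4)c(Nc4ccccc4)nc32)cc1` gives 54.8%
compound 2 `O=c1c2c(Nc3ccc(Cl)cc3)nn(-c3ccccc3)c2nc(Nc2ccccc2)n1-c1ccccc1` gives 44%
compound 3 `O=c1c2c(Nc3ccc(Cl)cc3)nn(-c3ccc([N+](=O)[O-])cc3)c2nc(Nc2ccccc2)n1-c1ccccc1` gives 39%

All three numbers come from a functional assay on the whole organism (strain Wistar albino) for inhibition, with Rattus norvegicus as the target, read by paw edema, with a stated time of 2 h, at a dose of 25 mg/kg by the oral route; on this read-out higher numbers stand for more inhibition at the one dose given (going by the name of the read-out) and lower numbers for less inhibition. Compound 3 has the lowest number of the three; compound 2 sits closest to it, and compound 1 sits furthest away, beyond the scatter. Going by the values given here, the only step between measured compounds that differ in one place is a number 5 percentage points lower from compound 2 to compound 3 (within the scatter), where a nitro replaces a hydrogen on an aromatic carbon.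

Compound 4 `NS(=O)(=O)c1ccc(-n2nc(Nc3ccc(Cl)cc3)c3c(=O)n(-c4ccccc4)c(Nc4ccccc4)nc32)cc1` has not yet been measured. It differs from compound 3 in one place: sulfamoyl in place of nitro on an aromatic carbon.

Among the compounds with values here, no measured step shows exactly this exchange, but two comparisons bear on it. The step from compound 2 to compound 3 shows what adding the nitro did, and it stayed within the scatter. Compound 1, which carries the sulfamoyl, and compound 2, which carries hydrogen at that place, show values that differ by more than the scatter, with compound 1 the higher. Compound 1 also shares the sulfamoylphenyl with compound 4. Taken together, compound 4 is expected to give a higher number than compound 3, with the estimated step of a number 11 percentage points higher from compound 3 to compound 4 (beyond the scatter). Compound 4 is therefore estimated at 50%, expected to fall between 40% and 60%.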

Compound 4, a percentage reported as inhibition, in the whole organism at one dose (the size of the read-out at that dose, not a potency): 56.3%
Compound 4: the middle estimate sits 6.3 percentage points below what was measured; low and high end bracket the measured number.
By their numbers in this assay, from the lowest: compounds 3 and 2 (each within the scatter of the next); then compounds 1 and 4 (each within the scatter of the next).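

In this assay, the exchange of 4-nitrophenyl for 4-sulfamoylphenyl can now be read directly on one shared core (a number 17.3 percentage points higher from compound 3 to compound 4 (beyond the scatter)). Sulfamoyl in place of hydrogen at this same place also shifts the number beyond the scatter (a number 12.3 percentage points higher from compound 2 to compound 4 (beyond the scatter)), which nitro in place of hydrogen did not do (a number 5 percentage points lower from compound 2 to compound 3 (within the scatter)), so among these groups on this core only the sulfamoyl moves the read-out clearly. Going by these compounds alone, the new compound also gives the first reading of chloro in place of hydrogen with the sulfamoyl present, and that change stays within the scatter (a number 1.5 percentage points higher from compound 1 to compound 4 (within the scatter)).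

Nothing available here explains why the sulfamoyl stands apart. From the compounds shown here alone, it also remains open whether a carboxylic acid, an amine or a methylsulfonyl at this place would give a similar number.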